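Compound 2 to compound 4: an aryl swap

This account rests on a few compounds, and the source may have more. Where it says the series, first, only, none or still open, it means among the compounds named here.

In a functional assay on DU-145 cells (Homo sapiens) for inhibition, read by trypan blue exclusion, with a stated time of 96 h (on this read-out higher numbers stand for weaker inhibition of growth and lower numbers for stronger inhibition of growth), compound 2 (`O=C(/C(=C\c1ccc(Cl)cc1Cl)S(=O)(=O)c1ccc(Br)cc1)c1ccc(Cl)cc1`) reads 50000 nM and compound 3 (`COc1ccc(/C=C(\C(=O)c2ccc(Br)cc2)S(=O)(=O)Cc2ccc(Cl)cc2)cc1`) reads 25000 nM within the scatter of each other. Compound 1 (`COc1ccc(/C=C(/SCc2ccc(F)cc2)C(=O)c2ccc(Cl)cc2)c(OC)c1OC`) reads 10000 nM as a lower number than compound 2, beyond the scatter. Compound 2 therefore shares the weak end of this small set with compound 3. Compound 4 (`Cc1ccc(C)c(/C=C(\C(=O)c2ccc(Cl)cc2)S(=O)(=O)c2ccc(Br)cc2)c1`) has 2,5-dimethylphenyl in place of 2,4-dichlorophenyl on a double-bonded chain carbon bound to a double-bonded chain carbon. Going by the values given here, no measured pair isolates this change, so the evidence is thin. The expected step of a 1.7-fold lower number from compound 2 to compound 4 (0.22 log units; within the scatter) in this assay is small, toward a lower number and not beyond the scatter. The estimated value for compound 4 is 30000 nM (expected range 10000 nM to 70000 nM).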

Compound 4, concentration for 50% growth inhibition: 1000 nM
Compound 4: middle estimate off by 30-fold (1.48 log units), on the high side, outside the stated range (below it).
By their numbers in this assay, from the lowest: compound 4; then compound 1; then compounds 3 and 2 (each within the scatter of the next).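

In this assay, going by these compounds alone, the aryl group on a double-bonded chain carbon bound to a double-bonded chain carbon proves a strong lever on growth inhibition: 2,5-dimethylphenyl in place of 2,4-dichlorophenyl gives a 50-fold lower number from compound 2 to compound 4 (1.70 log units; beyond the scatter) as the first single-place comparison. No measurement at hand accounts for this step.

This one pair cannot separate the exchange of chlorine for methyl from the shift in ring positions. A 2,5-dichlorophenyl or 2,4-dimethylphenyl group would separate the two, while an aminophenyl group would test a different kind of substituent at this position.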